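Working notes: nitro in place of hydrogen on the benzoyl

This account rests on a few compounds, and the source may have more. Where it says the series, first, only, none or still open, it means among the compounds named here.

Measured so far:
compound 1 `C=C1C(=O)[C@@]23C(=O)OC[C@]4(C(=O)CCC(C)(C)[C@H]4C=O)[C@@H]2CC[C@@H]1[C@H]3OC(=O)c1ccccc1` gives 1920 nM
compound 2 `C=C1C(=O)[C@@]23C(=O)OC[C@]4(C(=O)CCC(C)(C)[C@H]4C=O)[C@@H]2CC[C@@H]1[C@H]3OC(=O)c1ccc(C)cc1` gives 2240 nM

Among the compounds with values here, in a functional assay on MGC-803 cells (Homo sapiens) for cytotoxicity, read by MTT assay, with a stated time of 72 h (on this read-out higher numbers stand for weaker inhibition and lower numbers for stronger inhibition), compound 1 gives 1920 nM as one of only two numbers so far, and it lies within the scatter of compound 2, so no order can be read between them. The change to compound 3 `C=C1C(=O)[C@@]23C(=O)OC[C@]4(C(=O)CCC(C)(C)[C@H]4C=O)[C@@H]2CC[C@@H]1[C@H]3OC(=O)c1ccc([N+](=O)[O-])cc1`, not yet measured, is nitro in place of hydrogen on an aromatic carbon, or benzoyl to (4-nitrophenyl)carbonyl. Within the data shown here, the one measured step that bears on it is a 1.2-fold higher number from compound 1 to compound 2 (0.07 log units; within the scatter), which is methyl in place of hydrogen on an aromatic carbon. Among the measured compounds shown here, that single step says little about a nitro group, and no nitro example has been measured. No step beyond the scatter is therefore expected in this assay, although the uncertainty is wide in either direction. The estimated step is a 1.0-fold lower number from compound 1 to compound 3 (0.00 log units; within the scatter) and it remains an expectation. For compound 3 the estimated value is 1900 nM, with an expected range from 750 nM to 4800 nM until the measurement is in.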

Compound 3, half-maximal inhibitory concentration: 3330 nM
The estimate for compound 3 lay 1.8-fold (0.24 log units) below the measured number, and the stated range covers the measured number.
By their numbers in this assay, from the lowest: compounds 1, 2 and 3 (each within the scatter of the next).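

Working notes, in this assay: on the aromatic carbon para to a large group, nitro in place of hydrogen gives a 1.7-fold higher number from compound 1 to compound 3 (0.24 log units; within the scatter) in this series, and nitro in place of methyl gives a 1.5-fold higher number from compound 2 to compound 3 (0.17 log units; within the scatter) on the same carbon. With a nitro group added to hydrogen and methyl, this place has now carried three different substituents without a step beyond the scatter, so compounds 1, 2 and 3 cannot be put in any order. The nitro group brings three heavy atoms and two hydrogen-bond acceptors to the benzoyl, yet the read-out does not separate it from the smaller methyl or from hydrogen, and nothing at hand accounts for the numbers.

Still open, from the compounds shown here alone, is whether an amine, a carboxylic acid or a longer alkyl chain on this aromatic carbon would give a step beyond the scatter, or whether any group here can move the number at all. Also open, going by these compounds, is whether the same groups would read alike on the other carbons of the ring, or whether replacing the benzoyl itself with an aliphatic acyl chain would matter more than substitution on it.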